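Replacing bromo with a larger aromatic extension in compound 3

The source may hold more compounds than are shown below. What is called first, only, known or untested is meant among the compounds shown, and "the series" means these compounds.

Values in an assay on isolated protein with Bile acid receptor (Homo sapiens) as the target; a higher number here means that more compound is needed for the effect, a lower number that less compound is needed:
Compound 1 `COC(=O)/C=C/c1cccc(N(Cc2ccc(-c3ccc(F)c(F)c3)cc2)C(=O)C2CCCCC2)c1`: 72 nM
Compound 2 `COC(=O)/C=C/c1cccc(N(Cc2ccc(-c3ccc(F)c(Cl)c3)cc2)C(=O)C2CCCCC2)c1`: 66 nM
Compound 3 `COC(=O)/C=C/c1cccc(N(Cc2ccc(Br)cc2)C(=O)C2CCCCC2)c1`: > 1000 nM

Compound 3 stands at the limit of this assay, (the limit of > 1000 nM in this assay, at which 1 of the 3 values shown sits); its value is a limit, not a number. Compound 4 `COC(=O)/C=C/c1cccc(N(Cc2ccc(/C=C/c3ccc(OC)cc3)cc2)C(=O)C2CCCCC2)c1` differs from compound 3 by 2-(4-methoxyphenyl)ethenyl in place of bromo on an aromatic carbon. For the measured compounds named here, two measured steps bear on this: an at least 13-fold higher number from compound 1 to compound 3 (1.14 log units; beyond the scatter) and an at least 15-fold higher number from compound 2 to compound 3 (1.18 log units; beyond the scatter), both large and beyond the scatter, and both run from a compound carrying a six-membered aromatic ring at this position to the bromo compound 3. The step to compound 4 reinstates such a ring, so a large decrease in this assay is expected, an at least 6.6-fold lower number from compound 3 to compound 4 (0.82 log units; beyond the scatter). Compound 4 is therefore estimated at 150 nM, with a range from 40 nM to 800 nM.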

Compound 4, half-maximal effective concentration: 208 nM
For compound 4 the middle estimate is 1.4-fold (0.14 log units) below the measured one; measured number inside the range.
By their numbers in this assay, from the lowest: compounds 2 and 1 (each within the scatter of the next); then compound 4. At a limit, above all of these: compound 3.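

In this assay, a six-membered aromatic ring held out through an ethenyl link also restores activity at this position, so direct attachment of the ring is not required: an at least 4.8-fold lower number from compound 3 to compound 4 (0.68 log units; beyond the scatter). The value of compound 3 is a limit, so this step is only a bound: the limit of > 1000 nM in this assay, at which 1 of the 4 values shown sits. The 2-(4-methoxyphenyl)ethenyl group still falls short of both directly attached halogenated phenyl groups, with a 3.2-fold higher number from compound 2 to compound 4 (0.50 log units; beyond the scatter) and a 2.9-fold higher number from compound 1 to compound 4 (0.46 log units; beyond the scatter).

The link and the ring substituents change together in these steps, so their contributions cannot be separated. Open too, as far as these compounds go, is how a saturated ethyl link, or an amine on the ring, would read here.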